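Pyrazole for sulfonamide on the biaryl core

The compounds below may be only part of what the source reports. "The series", "measured", "known", "first", "only" and "open" are said of these compounds alone.

Among the compounds with values here, compound 1 `COc1ccc(-c2cc(-c3ccc(S(=O)(=O)NC4CC4)cc3)cnc2N)cn1` is the only member of this series with a numerical value: in an in vitro ADME assay on microsomes from liver (Homo sapiens) for metabolic stability (a lower number here means that the compound disappears faster, a higher number that the compound lasts longer), compound 1 gives 1.9 h. The other value shown is a limit of the assay rather than a number. Compound 2 `COc1ccc(-c2cc(-c3ccc(S(C)(=O)=O)cc3C(F)(F)F)cnc2N)cn1` reaches > 4.16 h in this assay, which is a limit, so no number is available for it. The evidence for this reads (the limit of > 4.16 h in this assay, at which 1 of the 2 values shown sits). Within the data shown here, since compound 1 and compound 2 differ in more than one place, no single-point step between measured compounds can be drawn from the two values.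

Compound 3 `COc1ccc(-c2cc(-c3ccc(-n4cccn4)cc3)cnc2N)cn1` is not yet measured. It differs from compound 1 by 1H-pyrazol-1-yl in place of cyclopropylsulfamoyl on an aromatic carbon. Among the measured compounds shown here, no measured step of this kind exists. The expectation for this assay is a step from compound 1 to compound 3 of a 1.3-fold higher number from compound 1 to compound 3 (0.12 log units; within the scatter), most likely within the usual scatter, with a slight lean towards longer persistence. Compound 3 is therefore estimated at 2.5 h, within 0.9 h to 4.5 h, in this assay.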

Compound 3, half-life: 3.38 h
Estimate against measurement, compound 3: 1.4-fold (0.13 log units) below; the range from low to high includes it.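

In this assay, the position on an aromatic carbon, para to a large group, now has its first single-place step, and that step lies within the scatter (a 1.8-fold higher number from compound 1 to compound 3 (0.25 log units; within the scatter)). 1H-pyrazol-1-yl, a five-membered aromatic ring with no hydrogen-bond donor, can thus stand in place of cyclopropylsulfamoyl, with its sulfur, two oxygens, three-membered ring and hydrogen-bond donor, without a change in this read-out beyond the scatter. The values shown give no reason for this outcome.

Within the data shown here, compound 2 gives > 4.16 h, which is a limit of the assay, and it differs from compound 1 and from compound 3 in more than one place, leaving it with no step on this position. Open questions are whether a carboxylic acid, an amine or a longer chain at this position would also stay within the scatter of compound 1, and what trifluoromethyl alone does on the aromatic ring in this assay.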